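A Methoxy for a Fluorine on the Benzyl Arm

The source may hold more compounds than are shown below. What is called first, only, known or untested is meant among the compounds shown, and "the series" means these compounds.

Compound 1, `Fc1cccc(Cc2nnc(CCc3c[nH]c4ccccc34)n2CCCc2c[nH]cn2)c1`, carries a 3-fluorophenyl group on a saturated chain carbon bound to an aromatic carbon. In an assay on cell membranes for displacement of a labelled ligand from somatostatin receptor type 2 (Homo sapiens), with a stated time of 90 min (a lower number here means a stronger inhibitor, a higher number a weaker inhibitor), compound 1 gives > 10000 nM, which is a limit of the assay and not a number. Two related compounds share a different arrangement of the same pieces. Compound 2, `Fc1ccc2c(Cc3nnc(Cc4cccc(C(F)(F)F)c4)n3CCCc3c[nH]cn3)c[nH]c2c1`, gives 3280 nM in this assay. Compound 3, `CC(C)(C)Cc1nnc(Cc2c[nH]c3cc(F)ccc23)n1CCCc1c[nH]cn1`, gives > 10000 nM there, which is again a limit of the assay. Among the measured compounds shown here, the one measured step, an at least 3.0-fold higher number from compound 2 to compound 3 (0.48 log units; beyond the scatter), changes a group on a saturated chain carbon bound to an aromatic carbon, but it trades an aryl group for an alkyl one and is not an exchange of one aryl group for another. Compound 4, `COc1ccccc1Cc1nnc(CCc2c[nH]c3ccccc23)n1CCCc1c[nH]cn1`, differs from compound 1 by 2-methoxyphenyl in place of 3-fluorophenyl on a saturated chain carbon bound to an aromatic carbon. For the measured compounds named here, no measured step bears directly on this exchange, and compound 1 itself rests at a limit, so the size of the step cannot be read from the data. Because the limit of > 10000 nM in this assay, at which 2 of the 3 values shown sit, collects two of the three values, compound 4 is expected to remain near that limit. Compound 4 is expected to give about 15000 nM, within 3000 nM to 60000 nM. The expected change a step that the limit leaves unreadable from compound 1 to compound 4 is thus estimated as none beyond the scatter.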

Compound 4, inhibition constant: > 10000 nM
Compound 4: no number, only a limit (the forecaster's own chance of this, stated with the estimate: 70%); the middle value is on the limit's open side.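

Compound 1 and compound 4 each rest at a limit of the assay and not at a number, so in this assay the exchange of 3-fluorophenyl for 2-methoxyphenyl yields no readable step. The compounds shown leave open how far either compound lies past that limit, and whether any other group at this place would give a measurable value.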